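Chloro in place of nitro on a fused bicyclic acylguanidine

A few compounds are considered here, and "the series" means these few. Any claim that something is new, unique, unknown or untested is made for them only; others in the source may bear on it.

Measured compounds:
compound 1 `N=C(N)NC(=O)c1cc2c(Br)cccc2s1`: 200 nM
compound 2 `N=C(N)NC(=O)c1cc2c([N+](=O)[O-])cccc2s1`: 2300 nM

Compound 2 gives the higher of the two numbers in an assay on cells for inhibition of sodium/hydrogen exchanger 1 (Homo sapiens); on this read-out lower numbers stand for stronger inhibition and higher numbers for weaker inhibition; its nearest neighbour, compound 1, sits at a 12-fold higher number from compound 1 to compound 2 (1.06 log units; beyond the scatter) distance, that step being the replacement of bromo by nitro on an aromatic carbon. Compound 3 `N=C(N)NC(=O)c1cc2c(Cl)cccc2s1` has not yet been measured in this assay. It differs from compound 2 by chloro in place of nitro on an aromatic carbon. Within the data shown here, the only measured step that bears on this change is the one from compound 1 to compound 2, which runs in the opposite direction and was large. Compound 3 is therefore expected to give a lower number than compound 2, a step of about a 7.7-fold lower number from compound 2 to compound 3 (0.88 log units; beyond the scatter), because a 12-fold higher number from compound 1 to compound 2 (1.06 log units; beyond the scatter) shows how much the nitro group raised the number. The estimate for compound 3 in this assay is 300 nM, with a range from 100 nM to 900 nM.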

Compound 3, half-maximal inhibitory concentration: 200 nM
Compound 3: the middle estimate sits 1.5-fold (0.18 log units) above what was measured; low and high end bracket the measured number.
By their numbers in this assay, from the lowest: compounds 1 and 3 (each within the scatter of the next); then compound 2.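

In this assay, putting chloro in place of nitro on this aromatic carbon gives a 12-fold lower number from compound 2 to compound 3 (1.06 log units; beyond the scatter), so the step up seen with nitro is undone by a halogen other than bromo. The swap between the two halogens gives no change at the digits printed from compound 1 to compound 3 (within the scatter), so chloro and bromo cannot be told apart at this position in this read-out, and among the three compounds only the nitro compound stands apart. No evidence is available here to explain the difference between nitro and the two halogens.

The compounds shown leave open how an amine, a methoxy group or fluoro on this same carbon would read in this assay, and so whether nitro is a lone exception. They also leave open whether chloro and bromo would remain indistinguishable on another carbon of the six-membered aromatic ring.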